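A few compounds are considered here, and "the series" means these few. Any claim that something is new, unique, unknown or untested is made for them only; others in the source may bear on it.

- compound 1 `CCCCCN(CCCCC)CCCOc1ccc(S(=O)(=O)c2c(C(C)C)cn3ccccc23)cc1` gives 89.6 nM
- compound 2 `CC(C)c1cn2ccccc2c1S(=O)(=O)c1ccc(OCCCN(C)C)cc1` gives 390 nM

Going by the values given here, compound 1 holds the lower of the two numbers in a functional assay (aorta) with Rattus norvegicus as the target; a lower number here means a stronger inhibitor, a higher number a weaker inhibitor (its gap to the only neighbour: a 4.4-fold higher number from compound 1 to compound 2 (0.64 log units; beyond the scatter)). Compound 3 `CCCCCN(CCCCC)CCCOc1ccc(S(=O)(=O)c2c(CC)cn3ccccc23)cc1` differs from compound 1 by hydrogen in place of methyl on a saturated chain carbon bound to an aromatic carbon and a saturated chain carbon (hydrogen in place of methyl on a saturated chain carbon bound to an aromatic carbon and a saturated chain carbon, or isopropyl to ethyl). Among the compounds with values here, no measured step covers this place. Within the data shown here, the single measured step (dimethylamino in place of dipentylamino) lies elsewhere in the structure, so compound 2 offers only a rough scale through a 4.4-fold higher number from compound 1 to compound 2 (0.64 log units; beyond the scatter) and no direction. A smaller step is therefore expected in this assay, leaning towards a higher number and possibly not beyond the scatter. The estimated step is a 1.4-fold higher number from compound 1 to compound 3 (0.14 log units; within the scatter) (an expectation only). For compound 3 the expected value is 125 nM (estimated range 50 nM to 310 nM).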

Compound 3, half-maximal inhibitory concentration: 62.4 nM
Beside the measured number, compound 3's estimate is 2.0-fold (0.30 log units) above it; low and high end bracket the measured number.
By their numbers in this assay, from the lowest: compounds 3 and 1 (each within the scatter of the next); then compound 2.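

In this assay, isopropyl to ethyl on the dipentylamino series gives a step within the scatter (a 1.4-fold lower number from compound 1 to compound 3 (0.16 log units; within the scatter)), so this place on the core of compound 1 has so far shown no readable difference between the two groups. Going by these compounds alone, that contrasts with the one earlier change, dimethylamino in place of dipentylamino, whose step lies beyond the scatter (a 4.4-fold higher number from compound 1 to compound 2 (0.64 log units; beyond the scatter)); of the two places compared, only the amine end has so far separated compounds. No data on the reason for either result accompany these compounds.

From the compounds shown here alone, whether a larger group such as tert-butyl or cyclopentyl, or a smaller one such as methyl, holds the number at this place remains open. Equally open, going by these compounds, is whether ethyl gives a similar result when paired with dimethylamino.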